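The source may hold more compounds than are shown below. What is called first, only, known or untested is meant among the compounds shown, and "the series" means these compounds.

Measured so far in an ADME assay on a cell-free system (plasma, Homo sapiens) for protein binding
compound 1 `CO[C@@H](C)c1c(NC(=O)Nc2cnc(-n3nccn3)c(Cl)c2)cnc2cc(Cl)nn12` gives 98.3%
compound 2 `O=C(Nc1cnc(-n2nccn2)c(Cl)c1)Nc1cnc2cc(Cl)nn2c1C1CCOCC1` gives 98.8%

Going by the values given here, compound 2 lies within the scatter of compound 1, the only other measured compound. Compound 3 `COCc1c(NC(=O)Nc2cnc(-n3nccn3)c(Cl)c2)cnc2cc(Cl)nn12` has methoxymethyl in place of oxan-4-yl on an aromatic carbon on the same core. Among the compounds with values here, one measured step bears on this exchange, a 1.4-fold lower unbound fraction from compound 1 to compound 2 (0.15 log units; within the scatter) with oxan-4-yl in place of 1-methoxyethyl on an aromatic carbon. No shift beyond the scatter is therefore expected in this assay for this exchange. The estimated change is a 1.7-fold higher unbound fraction from compound 2 to compound 3 (0.22 log units; within the scatter) in the unbound fraction. Compound 3 is expected at 98% with an estimated range of 96.5% to 98.9% in this assay.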

Compound 3, plasma protein binding: 98.1%
The estimate for compound 3 lay 1.1-fold (0.02 log units) (unbound fraction) above the measured number, within the range that was stated.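

In this assay the ring at this aromatic carbon is not needed to hold the read-out: methoxymethyl in place of oxan-4-yl gives a 1.6-fold higher unbound fraction from compound 2 to compound 3 (0.20 log units; within the scatter) and stays within the scatter. Hydrogen in place of methyl on the chain carbon gives a 1.1-fold higher unbound fraction from compound 1 to compound 3 (0.05 log units; within the scatter) and also stays within the scatter, so this branch shows no measurable effect here. Nothing available explains why these steps are so small. The groups shown at this place are all ethers, and whether an amine or a carboxylic acid there would move this assay beyond the scatter remains open.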